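This account rests on a few compounds, and the source may have more. Where it says the series, first, only, none or still open, it means among the compounds named here.

Measured so far:
compound 1, `N#Cc1c(Cl)nc(SCC(=O)Nn2c(COc3ccc(Cl)cc3Cl)nc3ccccc3c2=O)nc1-c1ccc(Cl)cc1`: 68.4%
compound 2, `N#Cc1c(Nc2ccccc2)nc(SCC(=O)Nn2c(COc3ccc(Cl)cc3Cl)nc3ccccc3c2=O)nc1-c1ccc(Cl)cc1`: 56.1%

Both were tested in a functional assay on the whole organism (strain albino) for inhibition, with Rattus norvegicus as the target, read by paw edema, with stated times of 1 h and 3 h, at a dose of 100 mg/kg by the oral route; a higher number here means a stronger effect of the compound at the dose given, a lower number a weaker effect. Of the two numbers, compound 2 stands lowest: the change of anilino in place of chloro on an aromatic carbon gives a number 12.3 percentage points lower from compound 1 to compound 2 (beyond the scatter), a modest drop that lies beyond the scatter.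

Compound 3, `N#Cc1c(Nc2ccc(O)cc2)nc(SCC(=O)Nn2c(COc3ccc(Cl)cc3Cl)nc3ccccc3c2=O)nc1-c1ccc(Cl)cc1`, differs from compound 2 by one change, (hydroxy in place of hydrogen on an aromatic carbon). Within the data shown here, no measured step bears directly on this kind of change. Among the measured compounds shown here, the only step available, a number 12.3 percentage points lower from compound 1 to compound 2 (beyond the scatter), concerns a different group on a different carbon and offers no guide to adding a hydroxy group to the anilino ring. With nothing to point either way, the step from compound 2 to compound 3 is expected to stay within the scatter, a number 0.1 percentage points lower from compound 2 to compound 3 (within the scatter). Compound 3 is therefore estimated at 56%, within a range of 42% to 68%.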

Compound 3, a percentage reported as inhibition, in the whole organism at one dose (the size of the read-out at that dose, not a potency): 91.2%
Estimate against measurement, compound 3: 35.2 percentage points below; measured number above the stated range.
By their numbers in this assay, from the lowest: compound 2; then compound 1; then compound 3.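

In this assay, the anilino ring turns out to be a sensitive place: hydroxy in place of hydrogen, para to a large group on this six-membered aromatic ring, gives a number 35.1 percentage points higher from compound 2 to compound 3 (beyond the scatter), a large step from a change of a single heavy atom. The loss seen on replacing chloro with anilino does not hold for the substituted ring, as (4-hydroxyphenyl)amino in place of chloro gives a number 22.8 percentage points higher from compound 1 to compound 3 (beyond the scatter), which makes compound 3 the highest of the three at this single dose. Nothing available here explains why this small change has so large an effect.

From the compounds shown here alone, whether the gain is specific to hydroxy remains open, as a methoxy group, an amine or a fluorine atom at the same place could behave quite differently. It is also unclear whether the same hydroxy group would give a similar gain on a different core.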